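Aryl amide variation on the shared core: compound 4

This account rests on a few compounds, and the source may have more. Where it says the series, first, only, none or still open, it means among the compounds named here.

Three analogues share one core and differ only in the aryl group attached to the carbonyl carbon of the amide. Compound 1 `COc1ccccc1C(=O)Nc1ccc2[nH]cc(C3CCN(C)CC3)c2n1` gives 750 nM in an assay for binding affinity to 5-hydroxytryptamine receptor 1B (Homo sapiens), read by radioligand binding; on this read-out lower numbers stand for stronger inhibition and higher numbers for weaker inhibition. Compound 2 `CN1CCC(c2c[nH]c3ccc(NC(=O)c4cccc(F)c4)nc23)CC1` gives 1600 nM. Compound 3 `CN1CCC(c2c[nH]c3ccc(NC(=O)c4cccs4)nc23)CC1` gives 390 nM, the lowest of the three numbers; its gap to compound 1 stays within the scatter, while the gap to compound 2 lies beyond it. Compound 4 `CN1CCC(c2c[nH]c3ccc(NC(=O)c4ccncc4)nc23)CC1` is the next analogue: pyridin-4-yl in place of thiophen-2-yl on a carbonyl carbon. Going by the values given here, two measured steps bear on this kind of swap on the same carbonyl carbon: a 1.9-fold lower number from compound 1 to compound 3 (0.28 log units; within the scatter) and a 4.1-fold lower number from compound 2 to compound 3 (0.61 log units; beyond the scatter), both modest. Among the compounds with values here, changing the aryl group has so far moved this assay only by modest amounts, and no measured step involves a pyridin-4-yl, so the direction is open. Since compound 3 already holds the lowest number, a modest rise is the more likely outcome. Compound 4 is expected to give about 650 nM, within a range of 250 nM to 1600 nM. The expected step is then a 1.7-fold higher number from compound 3 to compound 4 (0.22 log units; within the scatter).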

Compound 4, inhibition constant: 330 nM
Estimate against measurement, compound 4: 2.0-fold (0.29 log units) above, and the stated range covers the measured number.
By their numbers in this assay, from the lowest: compounds 4, 3 and 1 (each within the scatter of the next, the first and the last beyond it); then compound 2.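

In this assay, pyridin-4-yl in place of thiophen-2-yl on the carbonyl carbon gives (a 1.2-fold lower number from compound 3 to compound 4 (0.07 log units; within the scatter)), so at this position a six-membered aromatic ring with one hetero atom cannot be told apart from a five-membered one. The pyridin-4-yl amide also stands clear of both substituted phenyl amides, with (a 4.8-fold lower number from compound 2 to compound 4 (0.69 log units; beyond the scatter)) and (a 2.3-fold lower number from compound 1 to compound 4 (0.36 log units; beyond the scatter)); the latter step lies beyond the scatter, whereas the thiophen-2-yl amide stayed within it against the same 2-methoxyphenyl amide. The data on hand offer no explanation for these steps.

Open, as far as these compounds go, is whether pyridin-3-yl or pyridin-2-yl would match pyridin-4-yl on this carbonyl carbon. Also open, from the compounds shown here alone, is whether an amine or a carboxylic acid on the pyridin-4-yl ring, or a longer chain in place of the ring, would hold these numbers.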